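The compounds below may be only part of what the source reports. "The series", "measured", "known", "first", "only" and "open" are said of these compounds alone.

Three compounds share one core and differ only in the aryl group on the hydrazone carbon. Compound 1 `Cn1c(=O)c(=O)n(C2CCCC2)c2nc(N/N=C/c3ccccc3)ncc21` carries an unsubstituted phenyl. In a functional assay on HCT-116 cells (Homo sapiens) for antiproliferative activity, read by MTT assay (on this read-out higher numbers stand for weaker inhibition and lower numbers for stronger inhibition), compound 1 reaches only the limit > 100000 nM. Compound 2 `Cc1cccc(/C=N/Nc2ncc3c(n2)n(C2CCCC2)c(=O)c(=O)n3C)c1` carries a 3-methylphenyl, and in this assay compound 2 likewise reaches only the limit > 100000 nM. Compound 3 `Cn1c(=O)c(=O)n(C2CCCC2)c2nc(N/N=C/c3ccc(S(C)(=O)=O)cc3)ncc21` carries a 4-(methylsulfonyl)phenyl and is the only one of the three to give a number in this assay: compound 3 gives 86600 nM. Both steps toward compound 3 sit on the limit of > 100000 nM in this assay, at which 2 of the 3 values shown sit, and so can only be bounded, as an at least 1.1-fold lower number from compound 1 to compound 3 (0.06 log units; that floor lies within the scatter) and an at least 1.1-fold lower number from compound 2 to compound 3 (0.06 log units; that floor lies within the scatter).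

Compound 4 `Cc1cc(C)c(/C=N/Nc2ncc3c(n2)n(C2CCCC2)c(=O)c(=O)n3C)c(C)c1` differs from compound 3 by 2,4,6-trimethylphenyl in place of 4-(methylsulfonyl)phenyl on a carbon with a double bond to nitrogen. Among the measured compounds shown here, the change removes the one group that set compound 3 apart from the two limit-bound compounds and installs methyls, as in compound 2. Compound 4 is therefore expected to fall back toward the limit, with an estimate of 150000 nM and a range from 60000 nM to 500000 nM in this assay. The expected step is a 1.7-fold higher number from compound 3 to compound 4 (0.24 log units; within the scatter).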

Compound 4, half-maximal inhibitory concentration: 7920 nM
Beside the measured number, compound 4's estimate is 19-fold (1.28 log units) above it; the whole stated range lies above it.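

In this assay, the aryl group on a carbon with a double bond to nitrogen can move the read-out well beyond the scatter, as shown by an 11-fold lower number from compound 3 to compound 4 (1.04 log units; beyond the scatter); the methylsulfonyl group is therefore not required for activity, and a 2,4,6-trimethylphenyl with no hydrogen-bond acceptors serves better. Methyl substitution is also not uniform in its outcome, since the change gives an at least 12-fold lower number from compound 2 to compound 4 (1.10 log units; beyond the scatter) and, against the unsubstituted phenyl, an at least 12-fold lower number from compound 1 to compound 4 (1.10 log units; beyond the scatter). Those last two steps are floors rather than exact sizes: the limit of > 100000 nM in this assay, at which 2 of the 4 values shown sit.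

The compounds shown leave open whether the number of methyls or their places on the ring matters, since 2,4,6-trimethylphenyl differs from 3-methylphenyl in both. They also leave open how a methoxy group, a chlorine or an amine on this ring would read.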